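Lengthening the Chain Once More

The compounds below may be only part of what the source reports. "The series", "measured", "known", "first", "only" and "open" are said of these compounds alone.

In a functional assay on brain (Rattus norvegicus, strain Wistar) for inhibition (on this read-out higher numbers stand for weaker inhibition and lower numbers for stronger inhibition), compound 1 `CCCCCCCc1ccc(-c2c(C)[nH]c(=O)n2C)cc1` gives 8400 nM. Compound 2 `CCCCCCCCCCc1ccc(-c2c(C)[nH]c(=O)n2C)cc1` gives 7900 nM, which stands level with compound 1, within the usual scatter. Compound 3 `CCCCCCCCCCCCCCc1ccc(-c2c(C)[nH]c(=O)n2C)cc1` carries a longer chain still: butyl in place of hydrogen on a saturated chain carbon, ten or more bonds along the chain from an aromatic carbon. Going by the values given here, one measured step bears on this, the similar lengthening a 1.1-fold lower number from compound 1 to compound 2 (0.03 log units; within the scatter), and it stayed within the scatter. Going by that single step, no change beyond the scatter is expected in this assay, although one step is thin evidence. The expected step is a 1.1-fold lower number from compound 2 to compound 3 (0.02 log units; within the scatter). For compound 3 the estimated value is 7500 nM, with an expected range of 3000 nM to 20000 nM.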

Compound 3, half-maximal inhibitory concentration: 43800 nM
For compound 3 the middle estimate is 5.8-fold (0.77 log units) below the measured one; measured number outside the range, above it.
By their numbers in this assay, from the lowest: compounds 2 and 1 (each within the scatter of the next); then compound 3.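

In this assay the chain cannot simply keep growing: adding butyl on a saturated chain carbon gives a 5.5-fold higher number from compound 2 to compound 3 (0.74 log units; beyond the scatter) and the whole heptyl addition gives a 5.2-fold higher number from compound 1 to compound 3 (0.72 log units; beyond the scatter) as inhibition weakens. The earlier lengthening stayed within the scatter, so the weakening appears only with this last addition. Nothing measured here accounts for the loss. Open, as far as these compounds go, is where the number starts to rise between the chains of compound 2 and compound 3. Also open, from the compounds shown here alone, is whether an amine at the chain end would restore inhibition.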